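A few compounds are considered here, and "the series" means these few. Any claim that something is new, unique, unknown or untested is made for them only; others in the source may bear on it.

Compound 1 `CC(=O)OCCc1c(-c2ccccc2Cl)c2cc(Cl)ccc2[nH]c1=O` and compound 2 `CCC(=O)OCCc1c(-c2ccccc2Cl)c2cc(Cl)ccc2[nH]c1=O` share one core and differ only in the ester chain. In an ADME assay on HepG2 2.2.15 cells (Homo sapiens) for cytotoxicity (on this read-out lower numbers stand for higher toxicity in this test and higher numbers for lower toxicity in this test), compound 1 gives 27000 nM, and compound 2 gives 95000 nM; that step, a 3.5-fold higher number from compound 1 to compound 2 (0.55 log units; beyond the scatter), came from a methyl in place of hydrogen on a saturated chain carbon bound to a carbonyl carbon. Compound 2 thus holds the highest number of the two, with compound 1 closest to it.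

Compound 3 `CC(=O)NCC(=O)OCCc1c(-c2ccccc2Cl)c2cc(Cl)ccc2[nH]c1=O` is not yet measured. It differs from compound 2 by acetamido in place of methyl on a saturated chain carbon bound to a carbonyl carbon. For the measured compounds named here, the only step with any bearing is the one to compound 2, a 3.5-fold higher number from compound 1 to compound 2 (0.55 log units; beyond the scatter), at the same chain carbon; it shows that altering this carbon can move the number modestly, but it does not cover an acetamido group. With nothing to point either way, the change from compound 2 to compound 3 is expected to be a 1.4-fold lower number from compound 2 to compound 3 (0.13 log units; within the scatter), and compound 3 is estimated at 70000 nM, between 20000 nM and 250000 nM.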

Compound 3, half-maximal cytotoxic concentration: 110000 nM
Compound 3: middle estimate off by 1.6-fold (0.20 log units), on the low side; low and high end bracket the measured number.
By their numbers in this assay, from the lowest: compound 1; then compounds 2 and 3 (each within the scatter of the next).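

At this chain carbon, putting the larger acetamido, with its hydrogen-bond donor and acceptor, in place of methyl gives a 1.2-fold higher number from compound 2 to compound 3 (0.06 log units; within the scatter) in this assay, so the two numbers cannot be told apart. Set against hydrogen at the same carbon, the acetamido compound gives a 4.1-fold higher number from compound 1 to compound 3 (0.61 log units; beyond the scatter), a modest step of about the same size as a 3.5-fold higher number from compound 1 to compound 2 (0.55 log units; beyond the scatter), so in these three compounds both substituents stand apart from hydrogen, while the much larger one adds nothing that can be read over methyl. Nothing available explains why these numbers fall as they do.

From the compounds shown here alone, whether an amine, a carboxylic acid or a longer chain at this carbon would keep the number at this level remains open. So does whether the acetamido group would behave the same way on a different core.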